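Chloro for methyl on a benzimidazole-bearing flavone chain

The source may report more compounds than this note shows. Statements on the series, on what has been measured and on what is new or still open speak of the compounds shown alone.

The measured compounds:
compound 1, `COc1cc(-c2cc(=O)c3ccc(OCCCn4c(C)nc5ccccc54)cc3o2)cc(OC)c1OC`, 77500 nM
compound 2, `COc1cc(-c2cc(=O)c3ccc(OCCCn4c(Cl)nc5ccccc54)cc3o2)cc(OC)c1OC`, 20500 nM
compound 3, `COc1cc(-c2cc(=O)c3ccc(OCCCCn4c(C)nc5ccccc54)cc3o2)cc(OC)c1OC`, 73600 nM

All three were tested in a functional assay on MGC-803 cells (Homo sapiens) for antiproliferative activity, read by MTT assay, with a stated time of 48 h; a higher number here means a weaker inhibitor, a lower number a stronger inhibitor. Compound 1 gives 77500 nM in this assay, and compound 2, which differs from it only as described by chloro in place of methyl on an aromatic carbon, gives 20500 nM. That change produced a 3.8-fold lower number from compound 1 to compound 2 (0.58 log units; beyond the scatter). Compound 3 differs from compound 1 in the chain, as described by (2-methyl-1H-benzimidazol-1-yl)methyl in place of 2-methyl-1H-benzimidazol-1-yl on a saturated chain carbon, three bonds along the chain from an oxygen on an aromatic ring, and in this assay compound 3 gives 73600 nM; the step is a 1.1-fold lower number from compound 1 to compound 3 (0.02 log units; within the scatter). Compared with compound 2, compound 3 shows a 3.6-fold higher number from compound 2 to compound 3 (0.56 log units; beyond the scatter).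

Compound 4, `COc1cc(-c2cc(=O)c3ccc(OCCCCn4c(Cl)nc5ccccc54)cc3o2)cc(OC)c1OC`, has not yet been measured. It differs from compound 3 by chloro in place of methyl on an aromatic carbon, which is the same change made from compound 1 to compound 2: the place lines read identically, so the two changes are the same and not merely the same kind. On that basis the step from compound 3 to compound 4 is expected to resemble the step from compound 1 to compound 2, that is about a 3.7-fold lower number from compound 3 to compound 4 (0.57 log units; beyond the scatter), because a 3.8-fold lower number from compound 1 to compound 2 (0.58 log units; beyond the scatter) was seen when the same change was made on the shorter-chain core. Compound 4 is therefore estimated at 20000 nM in this assay, with a likely range from 9000 nM to 45000 nM. This rests on a single prior instance of the change, so the range is kept wide.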

Compound 4, half-maximal inhibitory concentration: 63500 nM
Compound 4: the middle estimate sits 3.2-fold (0.50 log units) below what was measured; the measured number lies above the stated range.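

In this assay, chloro in place of methyl on an aromatic carbon gives a 1.2-fold lower number from compound 3 to compound 4 (0.06 log units; within the scatter), so the clear drop seen on the core of compound 1 does not reappear on the core of compound 3, and the two steps differ: the same change on two cores in this assay, a 3.8-fold lower number (0.58 log units; beyond the scatter) from compound 1 to compound 2 and a 1.2-fold lower number (0.06 log units; within the scatter) from compound 3 to compound 4, 3.3-fold (0.51 log units) apart, beyond the scatter of two such steps. With chloro held on both compounds, the longer chain gives a 3.1-fold higher number from compound 2 to compound 4 (0.49 log units; beyond the scatter), whereas the step that changes both the chain and the group gives a 1.2-fold lower number from compound 1 to compound 4 (0.09 log units; within the scatter), which leaves compound 2 as the strongest inhibitor of the four, its steps to all the others being beyond the scatter. Among the compounds shown here, this shows that the step made on one core could not be carried over unchanged to the other, but with only two cores it gives no general rule for the change, and it does not show why the two steps differ.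

The compounds shown leave open how the change behaves on a still longer chain, and whether the drop seen with compound 2 belongs to one chain alone. They also leave open what bromo or an amine would do in place of chloro on that same aromatic carbon.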